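One cyano out, one hydroxy in: an expected loss

A few compounds are considered here, and "the series" means these few. Any claim that something is new, unique, unknown or untested is made for them only; others in the source may bear on it.

Compounds measured in a functional assay on CHO cells for inhibition of metabotropic glutamate receptor 5 (Rattus norvegicus), read by FLIPR and calcium flux; a lower number here means a stronger inhibitor, a higher number a weaker inhibitor:
Compound 1, `Cc1ccc2ccc(-c3cccc(Cl)c3)cc2n1`, gives 14000 nM.
Compound 2, `Cc1ccc2ccc(-c3cccc(OC(F)(F)F)c3)cc2n1`, gives only a limit of the assay, > 10000 nM.
Compound 3, `Cc1ccc2ccc(-c3cc(C#N)cc(C#N)c3)cc2n1`, gives 2 nM.

Compound 3 holds the lowest of the two numbers, far below compound 1, while the value of compound 2 is a limit and cannot be ranked. Compound 4, `Cc1ccc2ccc(-c3cc(O)cc(C#N)c3)cc2n1`, differs from compound 3 by hydroxy in place of cyano on an aromatic carbon. Within the data shown here, the only measured single-place step, a step that the limit leaves unreadable from compound 1 to compound 2, runs into the limit of > 10000 nM in this assay, at which 1 of the 3 values shown sits, and so offers no size to lean on, and no measured step touches a cyano group. Only the gap between compound 1 and compound 3, with both cyano groups present in compound 3, suggests that losing one should cost potency. Compound 4 is therefore expected at 100 nM, between 10 nM and 2000 nM, a weakening step of a 50-fold higher number from compound 3 to compound 4 (1.70 log units; beyond the scatter).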

Compound 4, half-maximal inhibitory concentration: 360 nM
For compound 4 the middle estimate is 3.6-fold (0.56 log units) below the measured one, and the stated range covers the measured number.
By their numbers in this assay, from the lowest: compound 3; then compound 4; then compound 1.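

Among these compounds, this is the first readable step at this position: hydroxy in place of cyano on an aromatic carbon gives a 180-fold higher number from compound 3 to compound 4 (2.26 log units; beyond the scatter) in this assay. The other cyano group and the shared core stay the same, so this single change alone carries the whole loss. At this position, then, hydroxy, which brings a hydrogen-bond donor, does not stand in for cyano, which has none.

Nothing shown explains the size of this loss. From the compounds shown here alone, whether an amine, a methoxy group or a carboxylic acid at this position would keep more of the potency of compound 3 stays open.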